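Swapping one aryl group: what compound 3 might show

A few compounds are considered here, and "the series" means these few. Any claim that something is new, unique, unknown or untested is made for them only; others in the source may bear on it.

Measured so far:
Compound 1, `C=CCn1c(=O)/c(=C\c2cccc(Cl)c2)[nH]c(=O)/c1=C\c1ccccc1OC`, gives 8900 nM in a functional assay on Huh-7 cells (Homo sapiens) for cytotoxicity, read by CCK-8 assay, with a stated time of 72 h; on this read-out lower numbers stand for stronger inhibition and higher numbers for weaker inhibition.
Compound 2, `C=CCn1c(=O)/c(=C\c2ccccc2OC)[nH]c(=O)/c1=C\c1ccccc1OC`, gives 21200 nM in this assay.

Compound 2 carries the highest of the two numbers measured, and its nearest neighbour is compound 1; the step of a 2.4-fold higher number from compound 1 to compound 2 (0.38 log units; beyond the scatter) separates them, so compound 2 is the weaker inhibitor of the pair by more than the usual scatter.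

Compound 3, `C=CCn1c(=O)/c(=C\c2cc(F)ccc2C)[nH]c(=O)/c1=C\c1ccccc1OC`, has not yet been measured. It differs from compound 2 in one place: 5-fluoro-2-methylphenyl in place of 2-methoxyphenyl on a double-bonded chain carbon bound to an aromatic carbon.

Going by the values given here, the only measured step that touches the same place is a 2.4-fold higher number from compound 1 to compound 2 (0.38 log units; beyond the scatter), in which a halogen-bearing phenyl gave way to the methoxy-bearing one and the number rose. Among the compounds with values here, compound 3 brings a halogen-bearing phenyl back in at that place, though with a different pattern of substituents, so the direction of that step is the only guide and its size should not be relied on closely.

Compound 3 is therefore expected to show a modestly lower number than compound 2, a step of about a 1.8-fold lower number from compound 2 to compound 3 (0.25 log units; within the scatter), with an estimate of 12000 nM and a plausible range from 5000 nM to 30000 nM in this assay.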

Compound 3, half-maximal inhibitory concentration: 5600 nM
Estimate against measurement, compound 3: 2.1-fold (0.33 log units) above, within the range that was stated.
By their numbers in this assay, from the lowest: compounds 3 and 1 (each within the scatter of the next); then compound 2.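

In this assay, a 3.8-fold lower number from compound 2 to compound 3 (0.58 log units; beyond the scatter) shows that a second group, 5-fluoro-2-methylphenyl, also moves the number away from that of compound 2, beyond the scatter and in the same direction as 3-chlorophenyl. The other comparison gives a 1.6-fold lower number from compound 1 to compound 3 (0.20 log units; within the scatter), which lies within the scatter, so 3-chlorophenyl and 5-fluoro-2-methylphenyl cannot be told apart here, although they carry different substituents; of the three groups at this place, only 2-methoxyphenyl stands apart. Nothing available explains why these groups shift the number as they do.

On these data alone, the group in compound 3 carries both a fluorine and a methyl, so the separate share of each in the step from 2-methoxyphenyl remains unknown, and a phenyl with only one of them would be needed to separate the two. All three groups are substituted phenyl rings carrying no charge, which leaves open how a phenyl bearing a carboxylic acid or an amine, or a plain alkyl chain in place of the ring, would behave at this place.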